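Trifluoromethyl in Place of Ethyl: An Expected Step

The source may hold more compounds than are shown below. What is called first, only, known or untested is meant among the compounds shown, and "the series" means these compounds.

Compound 3 `CCc1ccc2oc(N3CCN(C)CC3)nc2c1` reaches only the limit of a functional assay on ileum (strain Hartley) for agonist activity at 5-hydroxytryptamine receptor 3A (Cavia porcellus) (on this read-out higher numbers stand for higher potency (the scale is a negative logarithm) and lower numbers for lower potency), giving < 4. Compound 1 `CN1CCN(c2nc3cc(C(C)(C)C)ccc3o2)CC1` likewise gives only a limit in this assay, < 4. Compound 2 `CN1CCN(c2nc3cc([N+](=O)[O-])ccc3o2)CC1` gives 6.1 in this assay. The steps of a number at least 2.10 log units higher from compound 1 to compound 2 (beyond the scatter) and a number at least 2.10 log units lower from compound 2 to compound 3 (beyond the scatter) show that both alkyl-bearing compounds sit at the floor noted in the limit of < 4 in this assay, at which 2 of the 3 values shown sit, while the nitro-bearing compound stands well above it. Compound 4 `CN1CCN(c2nc3cc(C(F)(F)F)ccc3o2)CC1` differs from compound 3 by trifluoromethyl in place of ethyl on an aromatic carbon. Among the measured compounds shown here, no measured step covers this exact change; the alkyl-to-nitro steps show only that a change at this position can shift potency by a large amount. Compound 4 is therefore expected to give about 4.8, within 3.6 to 6, an estimated step of a number at least 0.80 log units higher from compound 3 to compound 4 (beyond the scatter) that may itself end at a limit.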

Compound 4, negative logarithm of the half-maximal effective concentration: < 4
Compound 4 ended at the assay's limit (the forecaster's own chance of this, stated with the estimate: 40%); at least 0.80 log units between middle value and limit.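

With trifluoromethyl on this aromatic carbon, compound 4 joins compound 1 and compound 3 at the floor of this assay: the limit of < 4 in this assay, at which 3 of the 4 values shown sit. Trifluoromethyl in place of nitro gives a number at least 2.10 log units lower from compound 2 to compound 4 (beyond the scatter) and so, of the four groups shown at this position, only the nitro of compound 2 stands clear of the limit. The steps from compound 1 and from compound 3 to compound 4 cannot be read, and nothing orders these three compounds.

The compounds shown leave open whether a reading at this position belongs to nitro alone or would also appear with a nitrile, an amine or a carboxylic acid.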